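A few compounds are considered here, and "the series" means these few. Any claim that something is new, unique, unknown or untested is made for them only; others in the source may bear on it.

Working notes on the series. Compound 1 `CC(C)(C)c1cc(/C=C/C(=O)NCCC2CCN(Cc3ccccc3)CC2)cc(C(C)(C)C)c1O` in an assay on isolated protein for inhibition of Amine oxidase [flavin-containing] B (Homo sapiens), read by fluorescence, with stated times of 15 min and 20 min (a higher number here means a weaker inhibitor, a lower number a stronger inhibitor), gives 8500 nM. Compound 2 `Cc1ccc(CN2CCC(CCNC(=O)/C=C/c3cc(C(C)(C)C)c(O)c(C(C)(C)C)c3)CC2)cc1` in this assay gives 8900 nM, and compound 3 `CC(C)(C)c1cc(/C=C/C(=O)NCCC2CCN(Cc3ccccc3F)CC2)cc(C(C)(C)C)c1O` gives 7400 nM. Compound 3 holds the lowest of the three numbers, nearest to compound 1 and furthest from compound 2, but both gaps lie within the scatter, so no order among the three can be read. The steps across the benzyl group so far, a 1.0-fold higher number from compound 1 to compound 2 (0.02 log units; within the scatter), a 1.1-fold lower number from compound 1 to compound 3 (0.06 log units; within the scatter) and a 1.2-fold lower number from compound 2 to compound 3 (0.08 log units; within the scatter), all stay within the scatter.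

Compound 4 `CC(C)(C)c1cc(/C=C/C(=O)NCCC2CCN(Cc3cccc(F)c3)CC2)cc(C(C)(C)C)c1O` is not yet measured in this assay. Against compound 3 the change is 3-fluorophenyl in place of 2-fluorophenyl on a saturated chain carbon bound to an amine nitrogen in a ring. Within the data shown here, the steps that bear on it are those that also vary the substituent on this aromatic ring, and none of them moved the number beyond the scatter, so no step beyond the scatter is expected here either, in either direction. The expected step is a 1.0-fold higher number from compound 3 to compound 4 (0.01 log units; within the scatter). For compound 4 the estimate in this assay is 7500 nM, with a range from 4000 nM to 14000 nM.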

Compound 4, half-maximal inhibitory concentration: 6500 nM
The estimate for compound 4 lay 1.2-fold (0.06 log units) above the measured number; low and high end bracket the measured number.
By their numbers in this assay, from the lowest: compounds 4, 3, 1 and 2 (each within the scatter of the next).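

Moving the fluoro group from 2-fluorobenzyl to 3-fluorobenzyl, on a saturated chain carbon bound to an amine nitrogen in a ring, gives (a 1.1-fold lower number from compound 3 to compound 4 (0.06 log units; within the scatter)), so the two fluorobenzyl compounds cannot be told apart in this assay. Against the plain benzyl and 4-methylbenzyl groups, the 3-fluorobenzyl group also stays within the scatter, with (a 1.3-fold lower number from compound 1 to compound 4 (0.12 log units; within the scatter)) and (a 1.4-fold lower number from compound 2 to compound 4 (0.14 log units; within the scatter)), so every substituent change shown at this ring leaves the number unresolved. No supporting measurement bears on this result.

The compounds shown leave open whether a methoxy, nitrile or dimethylamino group on this ring would move the number beyond the scatter. They also leave open whether a phenethyl group in place of the benzyl group would do so.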